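The compounds below may be only part of what the source reports. "The series", "measured", "known", "first", "only" and "open" are said of these compounds alone.

The study measured two compounds in an ADME assay on HepG2 cells (Homo sapiens) for cytotoxicity, read by CellTiter-Glo and resazurin assay, with a stated time of 72 h; on this read-out lower numbers stand for an effect already at smaller amounts and higher numbers for an effect only at larger amounts of compound. Compound 1, `CC(=O)Nc1cccc(-c2ccc(C(=O)N(Cc3cccc(OCCCCCC(=O)O)c3)C(C)C)cc2)c1`, carries a 3-acetamidophenyl group on the shared core. In this assay compound 1 gives only a limit, > 26000 nM. Compound 2, `CC(C)COc1cccc(-c2ccc(C(=O)N(Cc3cccc(OCCCCCC(=O)O)c3)C(C)C)cc2)c1`, differs from compound 1 in one place. In this assay compound 2 likewise gives only a limit, > 26000 nM. For the measured compounds named here, the single measured step, a step that the two limits leave unreadable from compound 1 to compound 2, is therefore of unreadable size, and both values sit at the limit of > 26000 nM in this assay, at which 2 of the 2 values shown sit, so compound 1 stands at the edge of the assay rather than at a number.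

The unmeasured compound 3, `CC(C)N(Cc1cccc(OCCCCCC(=O)O)c1)C(=O)c1ccc(-c2ccc3c(c2)OCCO3)cc1`, differs from compound 1 by 2,3-dihydro-1,4-benzodioxin-6-yl in place of 3-acetamidophenyl on an aromatic carbon. Going by the values given here, no measured step bears on this exchange: the only step measured, between compound 1 and compound 2, changes a group on the same ring and is unreadable, and nothing here separates any substituent from another. Compound 3 is therefore expected to behave like compound 1, with a step that the limit leaves unreadable from compound 1 to compound 3 expected to stay within the scatter. The estimate for compound 3 in this assay is 30000 nM, with a range from 15000 nM to 80000 nM, most likely again reported as a limit.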

Compound 3, half-maximal effective concentration: > 21900 nM
Compound 3: a limit, no number (the forecaster's own chance of this, stated with the estimate: 75%); the middle value is on the limit's open side.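

In this assay compound 3 gives only a limit, > 21900 nM. The steps from compound 1 to compound 3 and from compound 2 to compound 3 cannot be read, as all three values are limits. Compound 1, compound 2 and compound 3 leave open whether exchanging these groups on the shared core changes the cytotoxic concentration at all.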